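The source may report more compounds than this note shows. Statements on the series, on what has been measured and on what is new or still open speak of the compounds shown alone.

Compound 1 `COc1ccc(C(/C=C/c2ccc(Cl)cc2)=N/O)cc1`: 291000 nM
Compound 2 `COc1ccc(/C=C/C(=N\O)c2ccc(OC)cc2)cc1`: 2170000 nM

In an ADME assay on cells (Mus musculus, strain Balb/c) for cytotoxicity, read by MTT assay, with a stated time of 48 h (a higher number here means that more compound is tolerated, a lower number that less compound is tolerated), compound 1 stands at the lower of the two numbers; its nearest neighbour is compound 2, reached by a 7.5-fold higher number from compound 1 to compound 2 (0.87 log units; beyond the scatter). Compound 3 `COc1ccc(C(/C=C/c2ccccc2)=N/O)cc1` differs from compound 1 in one place: hydrogen in place of chloro on an aromatic carbon. Within the data shown here, the only measured step that bears on this is the one from compound 1 to compound 2, a modest rise beyond the scatter for a different replacement at the same aromatic carbon. A smaller rise is therefore expected here, a 2.1-fold higher number from compound 1 to compound 3 (0.31 log units; beyond the scatter). Compound 3 is estimated at 600000 nM, within 250000 nM to 1500000 nM.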

Compound 3, half-maximal cytotoxic concentration: 28600 nM
Beside the measured number, compound 3's estimate is 21-fold (1.32 log units) above it, and the stated range ends above it.
By their numbers in this assay, from the lowest: compound 3; then compound 1; then compound 2.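

At this aromatic carbon, para to a large group, hydrogen does not fall between chloro and methoxy in this assay: there is a 10-fold lower number from compound 1 to compound 3 (1.01 log units; beyond the scatter), and a 76-fold lower number from compound 2 to compound 3 (1.88 log units; beyond the scatter). Both substituted compounds thus tolerate higher concentrations than the unsubstituted compound 3, which the chloro-to-methoxy step alone could not show. Nothing available explains this order. From the compounds shown here alone, it remains open whether other groups at this carbon, such as fluoro, an amine or a carboxylic acid, would also stand above hydrogen, and how they would rank against chloro and methoxy.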